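The source may report more compounds than this note shows. Statements on the series, on what has been measured and on what is new or still open speak of the compounds shown alone.

Measured compounds in a functional assay on A2780 cells (Homo sapiens) for inhibition, with a stated time of 72 h; a lower number here means a stronger inhibitor, a higher number a weaker inhibitor:

Compound 1 `CC1(C)CCNc2ccc(NC(=S)Nc3ccc(C(F)(F)F)cc3)cc21` gives 6000 nM.
Compound 2 `CC1(C)CCNc2ccc(NC(=S)Nc3ccc(OC(F)(F)F)cc3)cc21` gives 7100 nM.
Compound 3 `CN1c2ccc(NC(=O)Nc3ccc(C(F)(F)F)cc3)cc2C(C)(C)C(=O)C1(C)C` gives 2580 nM.

Compound 1 and compound 2 share one core; the only difference between them is trifluoromethoxy in place of trifluoromethyl on an aromatic carbon. The step of a 1.2-fold higher number from compound 1 to compound 2 (0.07 log units; within the scatter) shows that the two numbers lie within the scatter of each other, so no order between compound 1 and compound 2 can be drawn. Compound 3 has a different core, and the difference between the two cores is not broken down here. In this assay compound 3 has the lowest of the three numbers, with its steps to both compound 1 and compound 2 beyond the scatter.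

Compound 4 `CN1c2ccc(NC(=O)Nc3ccc(OC(F)(F)F)cc3)cc2C(C)(C)C(=O)C1(C)C` is not yet measured. It stands to compound 3 as compound 2 stands to compound 1: the change is trifluoromethoxy in place of trifluoromethyl on an aromatic carbon, the same change as between compound 1 and compound 2, made on the same place. Among the compounds with values here, the one measured instance of this change, from compound 1 to compound 2, moved the number only within the scatter. On that basis the step is expected to be small as well, a 1.2-fold higher number from compound 3 to compound 4 (0.07 log units; within the scatter), carried by compound 3 at 2580 nM. Compound 4 is therefore estimated at 3000 nM, with a range from 1500 nM to 6500 nM. Whether the second core responds to this change in the same way as the first is not known from a single measured pair.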

Compound 4, half-maximal inhibitory concentration: 2400 nM
The estimate for compound 4 lay 1.3-fold (0.10 log units) above the measured number, and the stated range covers the measured number.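

In this assay, trifluoromethoxy in place of trifluoromethyl on the aromatic carbon gives a 1.1-fold lower number from compound 3 to compound 4 (0.03 log units; within the scatter), so on this second core, as on the first, the two groups cannot be told apart by this read-out. In this series, the change therefore carries from one core to the other as a step too small to read, and the two steps cannot be told apart from each other: the same change on two cores in this assay, a 1.2-fold higher number (0.07 log units; within the scatter) from compound 1 to compound 2 and a 1.1-fold lower number (0.03 log units; within the scatter) from compound 3 to compound 4, 1.3-fold (0.10 log units) apart, within the scatter of two such steps. This does not show that the two cores respond identically, as it rests on a single pair per core with both steps inside the scatter, and it gives no reason why the two groups read alike, nor any indication of how the change would behave on a third core or in another assay.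

From the compounds shown here alone, it remains open whether a different group on the same aromatic carbon, such as a nitrile, an amine or a carboxylic acid, would move the number beyond the scatter on either core. Also open is which of the structural differences between the two cores goes with the difference in their numbers, as the compounds shown include no pair that separates those differences one place at a time.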